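Flipping Two Ring Centres in a Peroxide Acid

A few compounds are considered here, and "the series" means these few. Any claim that something is new, unique, unknown or untested is made for them only; others in the source may bear on it.

Compound 1 `C=C1CCCC(C)(C)C1CC[C@]1(C)CC[C@@H]([C@@H](C)C(=O)O)OO1` is a carboxylic acid built on a cyclic peroxide core. In a functional assay on U-251 cells (Homo sapiens) for inhibition (a higher number here means a weaker inhibitor of growth, a lower number a stronger inhibitor of growth), compound 1 gives only a limit, > 10000 nM, and not a number. Its methyl ester, compound 2 `C=C1CCCC(C)(C)C1CC[C@]1(C)CC[C@H]([C@@H](C)C(=O)OC)OO1`, gives 2910 nM in this assay. Compound 3 `C=C1CCCC(C)(C)C1(O)CC/C(C)=C/CC[C@]1(C)CC[C@@H]([C@@H](C)C(=O)OC)OO1`, a related ester, also gives only a limit, > 17500 nM. For the measured compounds named here, compound 1 thus sits at the weak end of the values shown, and no step between two measured compounds exists to gauge a change of the kind leading to compound 4. Compound 4 `C=C1CCCC(C)(C)C1CC[C@@]1(C)CC[C@H]([C@@H](C)C(=O)O)OO1` differs from compound 1 as follows: the two compounds have the same atoms and bonds; at least one stereo element is drawn with a configuration in one of them and without one in the other: 2 of 4 stereo elements differ; a stereocentre at a saturated ring carbon is drawn R in compound 1 and S in compound 4; a stereocentre at a saturated ring carbon is drawn S in compound 1 and R in compound 4. The step of a number no higher from compound 1 to compound 4 (the limit leaves the size open) is expected to be small, within the scatter or a modest gain at most. Compound 4 is estimated at 10000 nM, with a range from 3000 nM to 30000 nM.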

Compound 4, concentration for 50% growth inhibition: 4330 nM
For compound 4 the middle estimate is 2.3-fold (0.36 log units) above the measured one; the measured number falls inside the stated range.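

With atoms and bonds unchanged, reversing two stereocentres at saturated ring carbons gives an at least 2.3-fold lower number from compound 1 to compound 4 (0.36 log units; beyond the scatter) in this assay. For the compounds shown here, this is the first sign that the spatial arrangement at these ring carbons matters for this carboxylic acid, since no earlier pair offered such a step. The full size of the step stays open because compound 1 has only a limit: the limit of > 10000 nM in this assay, at which 1 of the 4 values shown sits.

The compounds shown leave open whether reversing one of these centres alone would be enough. They also leave open how an amide in place of the carboxylic acid would behave on the core of compound 4.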